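The source may report more compounds than this note shows. Statements on the series, on what has been measured and on what is new or still open speak of the compounds shown alone.

Compound 1 `COc1cc(-c2cc(/C=C/C(=O)c3ccc(N)cc3)[nH]n2)cc(OC)c1OC` gives -69% in a functional assay on UACC-62 cells (Homo sapiens) for cytotoxicity, read by sulforhodamine B assay, with a stated time of 48 h, tested at 10 uM; a higher number here means a weaker effect of the compound at the concentration tested, a lower number a stronger effect. Compound 2 `COc1ccc(C(=O)/C=C/c2cc(-c3cc(OC)c(OC)c(OC)c3)n[nH]2)cc1OC` gives -92%. Compound 3 `COc1ccc(C(=O)/C=C/c2cc(-c3cc(OC)c(OC)c(OC)c3)n[nH]2)cc1` gives -74%.

Compound 4 `COc1ccc(-c2cc(/C=C/C(=O)c3ccc(N)cc3)[nH]n2)cc1OC` is not yet measured. Its core and that of compound 2 differ by 4-aminophenyl in place of 3,4-dimethoxyphenyl on a carbonyl carbon. Between compound 2 and compound 3 the change is hydrogen in place of methoxy on an aromatic carbon, and this brought a number 18 percentage points higher from compound 2 to compound 3 (beyond the scatter), while a number 23 percentage points lower from compound 1 to compound 2 (beyond the scatter) marks the gap between the two cores. From compound 1 to compound 4 the change is hydrogen in place of methoxy on an aromatic carbon, the same kind of change on the other ring; around its place the carbon is additionally meta to a methoxy group. Because a number 18 percentage points higher from compound 2 to compound 3 (beyond the scatter) was modest, compound 4 is expected to show a step of about a number 17 percentage points higher from compound 1 to compound 4 (beyond the scatter) in this assay. Compound 4 is thus estimated at -52%, between -75% and -30%.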

Compound 4, a percentage reported as activity, at one concentration (the size of the read-out at that concentration, not a potency): 3%
Compound 4: the middle estimate sits 55 percentage points below what was measured, and the stated range ends below it.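

Putting hydrogen in place of methoxy on an aromatic carbon gave a number 72 percentage points higher from compound 1 to compound 4 (beyond the scatter), so the direction of the earlier step held, but its size did not carry over from one core to the other in this assay: the same change on two cores in this assay, a number 18 percentage points higher (beyond the scatter) from compound 2 to compound 3 and a number 72 percentage points higher (beyond the scatter) from compound 1 to compound 4, 54 percentage points apart, beyond the scatter of two such steps

A step measured on one core in this series therefore cannot be transferred at face value to the other. Going by these compounds alone, with only two such pairs, which also differ in the ring that carries the change, this does not show whether the core or the ring accounts for the gap.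

The compounds shown leave open whether a hydroxy group or a fluorine atom in that place would behave more like methoxy or like hydrogen. They also leave open whether an acetamide in place of the amino group would alter the size of the step.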